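A few compounds are considered here, and "the series" means these few. Any claim that something is new, unique, unknown or untested is made for them only; others in the source may bear on it.

For the measured compounds named here, only two compounds have been read so far in an ADME assay on microsomes (Homo sapiens) for metabolic stability; on this read-out higher numbers stand for a longer-lived compound and lower numbers for a shorter-lived compound. In this assay compound 1 `O=C(c1cscn1)N1CCC(C(=O)N2N=CC[C@H]2c2ccccc2)CC1` gives > 3 h, which is a limit and not a number. In this assay compound 2 `CC(C)C(=O)N1N=CCC1c1ccccc1` gives > 1.5 h, which is likewise only a limit, so the starting point of this step has no exact value. Compound 3 `CC(C)(CO)C(=O)N1N=CCC1c1ccccc1` keeps the core of compound 2 and differs in one place: hydroxymethyl in place of hydrogen on a saturated chain carbon bound to a carbonyl carbon and two saturated chain carbons. Hydroxymethyl takes the place of hydrogen on a saturated chain carbon bound to a carbonyl carbon and two saturated chain carbons, so isopropyl becomes 1-(hydroxymethyl)-1-methylethyl. Going by the values given here, no measured pair shows a change of this kind. The expected step that the limit leaves unreadable from compound 2 to compound 3 is therefore none beyond the scatter, in either direction. Compound 3 is estimated at 2.5 h, with an expected range from 1.2 h to 5 h.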

Compound 3, half-life: > 1.5 h
Compound 3 ended at the assay's limit (the forecaster's own chance of this, stated with the estimate: 55%); the middle value does not contradict the limit.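

Compound 2 and compound 3 both end at a limit in this assay, so no step can be read between them: the limit of > 1.5 h in this assay, at which 2 of the 3 values shown sit.

The compounds shown leave open the actual half-life of each and whether hydroxymethyl in place of hydrogen shifts it at all.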